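This account rests on a few compounds, and the source may have more. Where it says the series, first, only, none or still open, it means among the compounds named here.

Compound 2, `CCOC(=O)CCCCCOc1cccc(CN(C(=O)c2ccc(-c3cccc(OCc4ccccc4)c3)cc2)C(C)C)c1`, was tested in an ADME assay on Raji cells (Homo sapiens) for cytotoxicity, read by CellTiter-Glo and resazurin assay, with a stated time of 72 h; on this read-out higher numbers stand for an effect only at larger amounts of compound and lower numbers for an effect already at smaller amounts. In this assay compound 2 gives > 26000 nM, which is a limit of the assay and not a number. Compound 1, `CCOC(=O)CCCCCOc1cccc(CN(C(=O)c2ccc(-c3ccc4ccccc4c3)cc2)C(C)C)c1`, was run alongside it; in this assay compound 1 gives > 26000 nM, again a limit and not a measured number. Going by the values given here, both values thus sit at the limit of > 26000 nM in this assay, at which 2 of the 2 values shown sit, so no step between measured compounds can be stated, and compound 2 cannot be placed above or below compound 1 on these numbers.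

Compound 3, `CCOC(=O)CCCCCOc1cccc(CN(C(=O)c2ccc(-c3cccc(O)c3)cc2)C(C)C)c1`, differs from compound 2 by hydrogen in place of benzyl on an oxygen on an aromatic ring. With both measured compounds at the limit, no step beyond the scatter is expected from this change in this assay, and compound 3 is expected to give 30000 nM (range 12000 nM to 80000 nM), a step that the limit leaves unreadable from compound 2 to compound 3, most likely reported again only as a limit.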

Compound 3, half-maximal effective concentration: > 26000 nM
Compound 3 was reported as a limit (the forecaster's own chance of this, stated with the estimate: 75%); the middle value is on the limit's open side.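

In this assay compound 3 gives > 26000 nM as a limit and not a number. Going by these compounds alone, no step from compound 1 or compound 2 to compound 3 can be read: the limit of > 26000 nM in this assay, at which 3 of the 3 values shown sit. The compounds shown leave open whether any change to them would give this assay a measured number rather than a limit.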